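Methoxy to carbamoyl on the urea aryl partner

A few compounds are considered here, and "the series" means these few. Any claim that something is new, unique, unknown or untested is made for them only; others in the source may bear on it.

The three measured compounds share one core: compound 1 `COc1ccc(NC(=O)Nc2cc(C)nc3ccccc23)cc1`, compound 2 `COc1ccc(NC(=O)Nc2cc(C)nc3ccccc23)cc1F` and compound 3 `Cc1cc(NC(=O)Nc2cc(Cl)cc(Cl)c2)c2ccccc2n1`. In an ADME assay on BJ cells (Homo sapiens) for cytotoxicity, with a stated time of 72 h (a lower number here means that less compound is needed, a higher number that more compound is needed for the effect), compound 1 gives only a limit, > 25000 nM. In this assay compound 2 gives 26000 nM. Compound 3 likewise reaches only a limit in this assay, > 25000 nM. Going by the values given here, the single step between neighbours, a step that the limit leaves unreadable from compound 1 to compound 2, cannot be sized because of the limit of > 25000 nM in this assay, at which 2 of the 3 values shown sit. Compound 1 therefore stands at the limit, and nothing among the three values separates it from the others beyond the scatter.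

Compound 4 `Cc1cc(NC(=O)Nc2ccc(C(N)=O)cc2)c2ccccc2n1` differs from compound 1 by carbamoyl in place of methoxy on an aromatic carbon. Among the compounds with values here, no measured step covers this change; the one step that exists is a fluoro swap and is itself unreadable. With all three values sitting at or near the same limit, no step beyond the scatter is expected in this assay. Compound 4 is estimated at 30000 nM, with a range from 15000 nM to 80000 nM. The expected step that the limit leaves unreadable from compound 1 to compound 4 is within the scatter, most likely reported again as a limit.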

Compound 4, half-maximal effective concentration: > 25000 nM
Compound 4 ended at the assay's limit; the forecaster's own chance of this, stated with the estimate: 70%; the middle value does not contradict the limit.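

No step can be read from compound 1 to compound 4, because both compounds give only a limit: the limit of > 25000 nM in this assay, at which 3 of the 4 values shown sit.

The compounds shown leave open whether any change on the urea aryl partner gives a value clearly apart from this limit in this assay, and how large such a step would be.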